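Swapping the Aryl Group on the Ester Chain

The source may report more compounds than this note shows. Statements on the series, on what has been measured and on what is new or still open speak of the compounds shown alone.

In an assay on thoracic aorta for inhibition of Voltage-gated L-type calcium channel (Rattus norvegicus) (a lower number here means a stronger inhibitor, a higher number a weaker inhibitor), compound 2 `COC(OC)C1=C(C(=O)OC/C=C/c2ccc(Cl)cc2)C(c2cccc(Cl)c2)C(C(=O)O)=C(C)N1` gives 1400 nM, and it stands within the scatter of compound 1 `COC(OC)C1=C(C(=O)OC/C=C/c2cccc(Cl)c2)C(c2cccc(Cl)c2)C(C(=O)O)=C(C)N1`, which in this assay gives 1000 nM. Among the measured compounds shown here, the one measured step, a 1.4-fold higher number from compound 1 to compound 2 (0.15 log units; within the scatter), is small. Compound 3 `COc1cccc(/C=C/COC(=O)C2=C(C(OC)OC)NC(C)=C(C(=O)O)C2c2cccc(Cl)c2)c1` differs from compound 2 by 3-methoxyphenyl in place of 4-chlorophenyl on a double-bonded chain carbon bound to a double-bonded chain carbon. Because a 1.4-fold higher number from compound 1 to compound 2 (0.15 log units; within the scatter) lay within the scatter, a change of comparable size is expected for this further swap at the same place, with no step beyond the scatter in either direction. Compound 3 is therefore estimated at 1200 nM, within 450 nM to 3500 nM, which is expected to mean a 1.2-fold lower number from compound 2 to compound 3 (0.07 log units; within the scatter).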

Compound 3, half-maximal inhibitory concentration: 4400 nM
Beside the measured number, compound 3's estimate is 3.7-fold (0.56 log units) below it; the whole stated range lies below it.
By their numbers in this assay, from the lowest: compounds 1 and 2 (each within the scatter of the next); then compound 3.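

Among the compounds shown here, the change to 3-methoxyphenyl is the first at this place, on a double-bonded chain carbon bound to a double-bonded chain carbon, to go beyond the scatter in this assay: it gives a 3.1-fold higher number from compound 2 to compound 3 (0.50 log units; beyond the scatter), where the earlier swap did not. Methoxy in place of chloro on an aromatic carbon gives a 4.4-fold higher number from compound 1 to compound 3 (0.64 log units; beyond the scatter), so this place does respond to the group it carries. No measurement offered here accounts for this shift.

From the compounds shown here alone, it remains open whether a fluoro or hydroxy group on this ring would stay with compound 1 or fall with compound 3. Also open, going by these compounds, is how a longer chain carrying the same aryl groups would read.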